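This account rests on a few compounds, and the source may have more. Where it says the series, first, only, none or still open, it means among the compounds named here.

The four compounds share one core, and only the group on the ring nitrogen changes. Compound 1 `CC(C)c1cc(C(=O)N2CCc3c(sc(NC(=O)c4ccc(F)cc4)c3C#N)C2)[nH]n1` carries a (4-fluorophenyl)carbonyl on that nitrogen; in a functional assay on Chem-3 cells for antagonist activity at metabotropic glutamate receptor 1 (Homo sapiens), read by fluorescence and calcium flux (on this read-out higher numbers stand for weaker inhibition and lower numbers for stronger inhibition), compound 1 returns "not determined" (no result reported). Compound 3 `Cc1cc(C(=O)N2CCc3c(sc(NC(=O)c4ccc(Cl)cc4)c3C#N)C2)[nH]n1` differs from the others at the pyrazole, and in this assay compound 3 likewise returns "not determined" (no result reported). This leaves compound 2 `CC(C)c1cc(C(=O)N2CCc3c(sc(NC(=O)c4ccc(Cl)cc4)c3C#N)C2)[nH]n1` as the only member of the set with a number: in this assay compound 2 gives 12200 nM, so on the numbers shown compound 2 stands alone, with nothing to rank it against.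

Compound 4 `CC(C)c1cc(C(=O)N2CCc3c(sc(NCc4ccccc4)c3C#N)C2)[nH]n1` is the unmeasured partner of compound 2. The difference between them is benzyl in place of (4-chlorophenyl)carbonyl on a nitrogen on an aromatic ring, that is, ((4-chlorophenyl)carbonyl)amino becomes benzylamino. Within the data shown here, no step between two measured compounds is available to calibrate this change. With the carbonyl gone and the hydrogen-bond acceptor with it, the expected direction in this assay is toward weaker inhibition, by a step that could well exceed the usual scatter, though starting from a weak value the assay may simply return a limit.

Compound 4 is therefore estimated at 25000 nM, with a range from 8000 nM to 80000 nM. The expected step of a 2.0-fold higher number from compound 2 to compound 4 (0.31 log units; beyond the scatter) is a modest loss, because compound 2 already sits at 12200 nM and leaves little room to measure a larger one.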

Compound 4, half-maximal inhibitory concentration: 43200 nM
For compound 4 the middle estimate is 1.7-fold (0.24 log units) below the measured one, within the range that was stated.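

In this assay, among these compounds, the change from (4-chlorophenyl)carbonyl to benzyl on a nitrogen on an aromatic ring gives a 3.5-fold higher number from compound 2 to compound 4 (0.55 log units; beyond the scatter), the first step at this position that can be read in the set. It shows that inhibition at this position responds to the change, with ((4-chlorophenyl)carbonyl)amino giving the stronger inhibition of the pair, yet the carbonyl is not needed for a numerical result, as compound 4 still gives 43200 nM. Nothing shown here accounts for the size or direction of this step.

The change removes the carbonyl and the chlorine together, so these compounds cannot show which of the two accounts for the step, and a 4-chlorobenzyl group on the same nitrogen would separate them. Steps involving compound 1 and compound 3 cannot be read, which leaves the (4-fluorophenyl)carbonyl of compound 1 and the change at the other end of compound 3 without a comparison, and how a carboxylic acid or an amine on the benzyl ring of compound 4 would fare also remains open.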